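The source may report more compounds than this note shows. Statements on the series, on what has been measured and on what is new or still open speak of the compounds shown alone.

Compound 1 is `C[C@@H](C(=O)N1CCCCC1)N1CCN(S(=O)(=O)c2ccc(C(C)(C)C)cc2)CC1`; in an ADME assay on HepG2 cells (Homo sapiens) for inhibition, with a stated time of 48 h (a higher number here means that more compound is needed for the effect, a lower number that less compound is needed), compound 1 gives > 40000 nM, which is a limit of the assay rather than a number.
Compound 2 is `C[C@@H](C(=O)N1CCC(F)(F)CC1)N1CCN(S(=O)(=O)c2ccc(C(C)(C)C)cc2)CC1`; in this assay compound 2 gives > 40000 nM, again a limit.
Compound 3 is `CC(C(=O)N1CCC2(CC1)CC2)N1CCN(S(=O)(=O)c2ccc(C(C)(C)C)cc2)CC1`; in this assay compound 3 gives > 40000 nM, also a limit.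

Compound 3 therefore stands where every measured compound here stands: at the limit of > 40000 nM in this assay, at which 3 of the 3 values shown sit. Among the compounds with values here, no compound has yet produced a readable number in this assay. Within the data shown here, the only one-place step among the measured compounds, a step that the two limits leave unreadable from compound 1 to compound 2, cannot be sized, since both of its ends are limits.

Compound 4 is `CC(C(=O)N1CCc2cccnc2C1)N1CCN(S(=O)(=O)c2ccc(C(C)(C)C)cc2)CC1`. Compared with compound 3, (a group of 10 heavy atoms (8 carbon, 2 nitrogen; one six-membered non-aromatic ring with 1 hetero atom, one six-membered aromatic ring with 1 hetero atom) in place of a group of 8 heavy atoms (7 carbon, 1 nitrogen; one three-membered non-aromatic ring of carbon only, one six-membered non-aromatic ring with 1 hetero atom), on a carbonyl carbon).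

Among the measured compounds shown here, no measured step bears on this change with a readable size, so nothing in the data points to a step beyond the scatter in either direction. The expectation is that compound 4 behaves like compound 3 and the others, giving a limit again, with the estimated step of a number no higher from compound 3 to compound 4 (the limit leaves the size open). Compound 4 is estimated at 40000 nM, with a range from 20000 nM to 100000 nM.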

Compound 4, half-maximal effective concentration: > 40000 nM
Compound 4: a limit, no number (the forecaster's own chance of this, stated with the estimate: 85%); the middle value lies on the limit itself.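

In this assay compound 4 gives > 40000 nM, again a limit and not a number. With limits at both ends, the step between compound 3 and compound 4 cannot be read. The compounds shown leave open what change, if any, would give a readable number.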